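The source may report more compounds than this note shows. Statements on the series, on what has been measured and on what is new or still open speak of the compounds shown alone.

Measured so far in a functional assay on HCT-116 cells (Homo sapiens) for cytotoxicity, read by MTT assay, with a stated time of 72 h; on this read-out lower numbers stand for stronger inhibition and higher numbers for weaker inhibition:
Compound 1 `CCOc1cccc(/C=N/c2c(C)n(C)n(-c3ccccc3)c2=O)c1` gives 933000000 nM.
Compound 2 `Cc1c(/N=C/c2cccc([N+](=O)[O-])c2)c(=O)n(-c2ccccc2)n1C` gives 363000000 nM.

Among these two numbers compound 2 stands lowest; its only neighbour is compound 1, and the single measured step, a 2.6-fold lower number from compound 1 to compound 2 (0.41 log units; beyond the scatter), separates them. Compound 3 `Cc1c(/N=C/c2ccccc2)c(=O)n(-c2ccccc2)n1C` has not yet been measured. It differs from compound 2 by hydrogen in place of nitro on an aromatic carbon; the site is an aromatic carbon of a six-membered aromatic ring of carbon only, meta to a large group. For the measured compounds named here, only the step between compound 1 and compound 2 bears on this change, and only indirectly, since it exchanged an ethoxy group for the nitro group that is now removed, and its size was modest. A step of similar modest size in this assay, toward a higher number, is therefore expected, a 1.8-fold higher number from compound 2 to compound 3 (0.25 log units; within the scatter). Compound 3 is estimated at 650000000 nM, with a range from 250000000 nM to 1600000000 nM.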

Compound 3, half-maximal inhibitory concentration: 589000000 nM
Beside the measured number, compound 3's estimate is 1.1-fold (0.04 log units) above it; the measured number falls inside the stated range.
By their numbers in this assay, from the lowest: compounds 2, 3 and 1 (each within the scatter of the next, the first and the last beyond it).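

In this assay, replacing nitro with hydrogen on this aromatic carbon (a 1.6-fold higher number from compound 2 to compound 3 (0.21 log units; within the scatter)) and replacing ethoxy with hydrogen there (a 1.6-fold lower number from compound 1 to compound 3 (0.20 log units; within the scatter)) both stay within the scatter, so neither group is separated from hydrogen by a clear margin. The earlier comparison showed only that nitro and ethoxy differ from each other, and compound 3 now shows that this modest gap appears only when those two groups are set against one another, not when either is compared with hydrogen. No measurement is available to explain these results.

As far as these compounds go, whether an amine or a carboxylic acid on this carbon would move the number beyond the scatter remains open. Also open, from the compounds shown here alone, is whether nitro or ethoxy would give similar numbers on another carbon of this ring.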